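Meta-halogen series: the bromo to iodo step

The source may report more compounds than this note shows. Statements on the series, on what has been measured and on what is new or still open speak of the compounds shown alone.

Among the measured compounds shown here, compound 2 `O=C(O)/C(S)=C/c1cccc(Br)c1` gives the lowest of the two numbers so far in an assay on isolated protein for inhibition of Calpain-1 catalytic subunit (Sus scrofa) (on this read-out lower numbers stand for stronger inhibition and higher numbers for weaker inhibition), namely 8400 nM. Its nearest neighbour is compound 1 `O=C(O)/C(S)=C/c1cccc(F)c1`, which in this assay gives 31500 nM. For the measured compounds named here, the single measured step is a 3.8-fold lower number from compound 1 to compound 2 (0.57 log units; beyond the scatter), a change of the halogen on the aromatic carbon.

Compound 3 `O=C(O)/C(S)=C/c1cccc(I)c1` carries the same skeleton and differs from compound 2 only in this way: iodo in place of bromo on an aromatic carbon. Going by the values given here, the only step that bears on it is the one from fluoro to bromo just described, which was modest but beyond the scatter; there is no second halogen step to show whether a further change in the same direction continues, levels off, or reverses. Judged on that one step alone, a further lowering of the number in this assay is expected, smaller than the measured one and close to the edge of the scatter.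

For compound 3 a value of 4500 nM is expected, with a range from 2000 nM to 12000 nM. The expected step is a 1.9-fold lower number from compound 2 to compound 3 (0.27 log units; within the scatter).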

Compound 3, half-maximal inhibitory concentration: 23900 nM
The estimate for compound 3 lay 5.3-fold (0.73 log units) below the measured number; measured number above the stated range.
By their numbers in this assay, from the lowest: compound 2; then compounds 3 and 1 (each within the scatter of the next).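

Among the three halogens at this position the numbers do not move in one direction: in this assay the change from bromo to iodo gives a 2.8-fold higher number from compound 2 to compound 3 (0.45 log units; beyond the scatter), which runs against the earlier fluoro to bromo step instead of extending it. Iodo and fluoro cannot be told apart on this aromatic carbon (a 1.3-fold lower number from compound 1 to compound 3 (0.12 log units; within the scatter)), so compound 2 alone stands apart, with its steps to both other compounds beyond the scatter, and it is the strongest of the three in this read-out. Nothing at hand accounts for this turn at bromo.

Going by these compounds, whether the low number belongs to bromo alone stays open, and a chloro group on the same aromatic carbon would be the most direct test of that within the halogens. Equally open is whether the effect is tied to halogens at all, a question that a methyl or trifluoromethyl group at this place could address, and the three compounds shown say nothing about either group.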